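A few compounds are considered here, and "the series" means these few. Any claim that something is new, unique, unknown or untested is made for them only; others in the source may bear on it.

Compound 1 `CN1CCN(c2ccc(C3=NN(C(=O)c4ccc(F)cc4)C(c4ccc(N(C)C)cc4)C3)cc2)CC1`: 31.8%
Compound 2 `Cc1ccc(S(=O)(=O)N2N=C(c3ccc(N4CCN(C)CC4)cc3)CC2c2ccc(N(C)C)cc2)cc1`: 32.2%
Compound 3 `CN1CCN(c2ccc(C3=NN(S(=O)(=O)c4ccc(Br)cc4)C(c4ccc(N(C)C)cc4)C3)cc2)CC1`: 87.1%

In a functional assay on HCC1806 cells (Homo sapiens) for inhibition, read by sulforhodamine B assay, tested at 10 uM (on this read-out higher numbers stand for more inhibition at the one concentration tested (going by the name of the read-out) and lower numbers for less inhibition), compound 1 has the lowest of the three numbers. Its nearest neighbour is compound 2, with a step of a number 0.4 percentage points higher from compound 1 to compound 2 (within the scatter), and its furthest is compound 3, with a step of a number 55.3 percentage points higher from compound 1 to compound 3 (beyond the scatter); between those two the step of a number 54.9 percentage points higher from compound 2 to compound 3 (beyond the scatter) is also large. Compound 4 `CN(C)c1ccc(C2CC(c3ccc(-n4cncn4)cc3)=NN2C(=O)c2ccc(F)cc2)cc1` differs from compound 1 in 1H-1,2,4-triazol-1-yl in place of 4-methylpiperazin-1-yl on an aromatic carbon. For the measured compounds named here, none of the measured steps touches this position; all three change the group on the amine nitrogen in the ring or on its aromatic carbon. No step beyond the scatter is therefore expected, and compound 4 is estimated at 30%, between 10% and 55%, an expected step of a number 1.8 percentage points lower from compound 1 to compound 4 (within the scatter).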

Compound 4, a percentage reported as inhibition, at one concentration (the size of the read-out at that concentration, not a potency): 15.6%
Estimate against measurement, compound 4: 14.4 percentage points above; low and high end bracket the measured number.
By their numbers in this assay, from the lowest: compound 4; then compounds 1 and 2 (each within the scatter of the next); then compound 3.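

The position on the aromatic ring that carries 4-methylpiperazin-1-yl is not neutral: in this assay, the change to 1H-1,2,4-triazol-1-yl gives a number 16.2 percentage points lower from compound 1 to compound 4 (beyond the scatter), a modest step beyond the scatter. For the compounds shown here, the earlier compounds varied only the group on the amine nitrogen in the ring, so this is the first sign that this second place also matters. Nothing measured here accounts for the step.

The compounds shown leave open whether this change would act the same way with the (4-bromophenyl)sulfonyl group of compound 3. Going by these compounds, how a morpholine or a pyrazole at this place would read also remains open.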